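The source may hold more compounds than are shown below. What is called first, only, known or untested is meant among the compounds shown, and "the series" means these compounds.

Measured compounds:
compound 1, `CCC(C)n1ccc2cc(/C(C)=C/C(=O)Nc3ccccc3OCCCC(=O)O)ccc21`, 67 nM
compound 2, `CCCC(C)n1ccc2cc(/C(C)=C/C(=O)Nc3ccccc3OCCCC(=O)O)ccc21`, 7.8 nM
compound 3, `C/C(=C\C(=O)Nc1ccccc1OCCCC(=O)O)c1ccc2c(ccn2C(C)c2ccccc2)c1`, 19 nM

All three were tested in an assay on Prostate gland for inhibition of steroid 5-alpha-reductase (Rattus norvegicus); on this read-out lower numbers stand for stronger inhibition and higher numbers for weaker inhibition. Compound 2 differs from compound 1 by methyl in place of hydrogen on a saturated chain carbon, three bonds along the chain from an aromatic nitrogen, and that change gave an 8.6-fold lower number from compound 1 to compound 2 (0.93 log units; beyond the scatter). Compound 3 differs from compound 1 in its core by phenyl in place of ethyl on a saturated chain carbon bound to an aromatic nitrogen and a saturated chain carbon, a change that produced a 3.5-fold lower number from compound 1 to compound 3 (0.55 log units; beyond the scatter). Compound 2 and compound 3 stand apart by a 2.4-fold higher number from compound 2 to compound 3 (0.39 log units; beyond the scatter).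

Compound 4, `CCC(c1ccccc1)n1ccc2cc(/C(C)=C/C(=O)Nc3ccccc3OCCCC(=O)O)ccc21`, has not been measured. It differs from compound 3 by methyl in place of hydrogen on a saturated chain carbon, two bonds along the chain from an aromatic carbon and an aromatic nitrogen. Within the data shown here, this is the same kind of change as the one from compound 1 to compound 2, although the place is not the same: in compound 4 the methyl enters two bonds along the chain from an aromatic carbon and an aromatic nitrogen, while in compound 2 it entered three bonds along the chain from an aromatic nitrogen.

Because the earlier change gave an 8.6-fold lower number from compound 1 to compound 2 (0.93 log units; beyond the scatter), a gain is expected here too, though a smaller one given the different surroundings, estimated at a 3.2-fold lower number from compound 3 to compound 4 (0.50 log units; beyond the scatter). Compound 4 is therefore expected to give about 6 nM in this assay, with a plausible span from 2 nM to 20 nM.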

Compound 4, half-maximal inhibitory concentration: 19 nM
Compound 4: middle estimate off by 3.2-fold (0.50 log units), on the low side; low and high end bracket the measured number.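

The added methyl gave no change at the digits printed from compound 3 to compound 4 (within the scatter), so the gain seen when the chain of compound 1 was lengthened did not carry over to the chain that bears the phenyl ring. Set side by side in this assay, the two methyl steps differ: the same change on two cores in this assay, an 8.6-fold lower number (0.93 log units; beyond the scatter) from compound 1 to compound 2 and no change at the digits printed (within the scatter) from compound 3 to compound 4, 8.6-fold (0.93 log units) apart, beyond the scatter of two such steps The 1-phenylpropyl group also gives a 3.5-fold lower number from compound 1 to compound 4 (0.55 log units; beyond the scatter) and a 2.4-fold higher number from compound 2 to compound 4 (0.39 log units; beyond the scatter), but this single pair of steps does not show that a methyl never helps on a phenyl-bearing chain, and since the methyl enters at a different place in each pair, the effect of place cannot be separated from that of the surroundings.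

The compounds shown leave open whether an even longer chain on the saturated carbon bound to the aromatic nitrogen would change the number on either type of chain. They also leave open what a hydroxyl group or an amine at that chain would do.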